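Hydroxy for amino on the acylated chain

The source may report more compounds than this note shows. Statements on the series, on what has been measured and on what is new or still open speak of the compounds shown alone.

Values in a functional assay on NCI-H1975 cells (Homo sapiens) for antiproliferative activity; on this read-out lower numbers stand for stronger inhibition and higher numbers for weaker inhibition:
- compound 1 `CC(=O)N1CCCc2c(C)c3c(n2-c2ccc(C(N)=O)c(c2)N[C@@H](C)[C@@H]1C)CC(C)(C)CC3=O`: 20 nM
- compound 2 `Cc1c2c(n3c1CCCN(C(=O)CN)[C@@H](C)[C@H](C)Nc1cc-3ccc1C(N)=O)CC(C)(C)CC2=O`: 380 nM

Compound 2, at 380 nM, holds the higher of the two numbers in this assay. Compound 3 `Cc1c2c(n3c1CCCN(C(=O)CO)[C@@H](C)[C@H](C)Nc1cc-3ccc1C(N)=O)CC(C)(C)CC2=O` is not yet measured. It carries hydroxy in place of amino on a saturated chain carbon bound to a carbonyl carbon. Among the measured compounds shown here, one measured step bears on this place: a 19-fold higher number from compound 1 to compound 2 (1.28 log units; beyond the scatter), a large step beyond the scatter, with amino in place of hydrogen. For the measured compounds named here, no measured compound carries hydroxy there, so the size of the change remains uncertain. A partial return towards compound 1, which stands at 20 nM, is expected. The expected move is to a lower number, smaller than the step with amino in place of hydrogen: a 4.2-fold lower number from compound 2 to compound 3 (0.63 log units; beyond the scatter). The estimate for compound 3 is 90 nM, with an expected range of 25 nM to 320 nM.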

Compound 3, half-maximal inhibitory concentration: 54 nM
For compound 3 the middle estimate is 1.7-fold (0.22 log units) above the measured one, within the range that was stated.
By their numbers in this assay, from the lowest: compound 1; then compound 3; then compound 2.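

In this assay, hydroxy in place of amino on the saturated chain carbon bound to a carbonyl carbon gives a 7.0-fold lower number from compound 2 to compound 3 (0.85 log units; beyond the scatter), so the loss seen with amino at this place depends on which group is present and not simply on hydrogen being replaced. The recovery is partial, with a 2.7-fold higher number from compound 1 to compound 3 (0.43 log units; beyond the scatter), and hydrogen remains the best of the three groups at this place. Amino and hydroxy have matching computed counts of hydrogen-bond donors and acceptors, so those counts do not separate them, and no supporting data explain the difference between these groups.

As far as these compounds go, whether methoxy or dimethylamino at this place would stay closer to hydrogen or to amino remains open. Also open, from the compounds shown here alone, is how a longer chain, such as hydroxyethyl in place of hydroxymethyl, would compare with compound 3.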